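A few compounds are considered here, and "the series" means these few. Any claim that something is new, unique, unknown or untested is made for them only; others in the source may bear on it.

In an ADME assay on HEL cells (Homo sapiens) for cytotoxicity, with a stated time of 3 days (a higher number here means that more compound is tolerated, a lower number that less compound is tolerated), compound 1, `CCC1(Cc2ccccc2)OS(=O)(=O)C=C1OCc1ccc(F)cc1`, gives > 50000 nM, which is a limit of this assay and not a number. Compound 2, `CCC1(Cc2ccccc2)OS(=O)(=O)C=C1OCc1ccc(OC)cc1`, gives > 200000 nM, likewise a limit. Compound 3, `CCC1(Cc2ccccc2)OS(=O)(=O)C=C1OCc1ccc(Br)cc1`, gives 171000 nM.

Among the measured compounds shown here, compound 3 therefore stands as the only number among the three values in this assay; the other two are limits. Compound 4, `CCC1(Cc2ccccc2)OS(=O)(=O)C=C1OCc1ccc(C(F)(F)F)cc1`, differs from compound 3 by one change: trifluoromethyl in place of bromo on an aromatic carbon. For the measured compounds named here, of the measured steps, the one from compound 1 to compound 3 is a step that the limit leaves unreadable from compound 1 to compound 3, and the one from compound 2 to compound 3 is an at least 1.1-fold lower number from compound 2 to compound 3 (0.06 log units; that floor lies within the scatter). The substituent changes so far have given no step beyond the scatter, so the expected step of a 1.1-fold lower number from compound 3 to compound 4 (0.06 log units; within the scatter) is none beyond the scatter. Compound 4 is therefore estimated at 150000 nM, within 50000 nM to 300000 nM.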

Compound 4, half-maximal cytotoxic concentration: 99000 nM
Beside the measured number, compound 4's estimate is 1.5-fold (0.18 log units) above it, within the range that was stated.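

In this assay, trifluoromethyl on this aromatic carbon, para to a large group, gives a 1.7-fold lower number from compound 3 to compound 4 (0.24 log units; within the scatter), so a group with more heavy atoms than bromo brings no step beyond the scatter. The comparison with methoxy gives an at least 2.0-fold lower number from compound 2 to compound 4 (0.30 log units; that floor lies within the scatter), and that floor also stays within the scatter. Compound 1 gives only a limit, so its step to compound 4 cannot be read: the limit of > 50000 nM in this assay, at which 1 of the 4 values shown sits.

The compounds shown leave open whether an amine or a carboxylic acid at this place would bring a step beyond the scatter.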